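Swapping a selenium-bearing chain for a simple amino group

The source may hold more compounds than are shown below. What is called first, only, known or untested is meant among the compounds shown, and "the series" means these compounds.

Of the compounds shown here, three with a shared core have been tested in a functional assay on MDA-MB-231 cells (Homo sapiens) for inhibition, read by MTT assay, with a stated time of 48 h; a higher number here means a weaker inhibitor, a lower number a stronger inhibitor. Compound 1, `COc1ccc(N(C)c2nc(C)nc3ccccc23)cc1OCCCCCC[Se]C#N`, gives 3550 nM and is the weakest of the three. Compound 2, `Cc1nc(N(C)c2ccc(OCC[Se]C#N)cc2)c2ccccc2n1`, carries a shorter chain ending in the same selenium-bearing group and reaches 317 nM. Compound 3, `C[Se]c1ccc(N(C)c2nc(C)nc3ccccc23)cc1Cl`, with selenium attached directly to the aromatic ring, reaches 7 nM; in this assay it is the strongest inhibitor among them.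

Compound 4, `COc1ccc(N(C)c2nc(C)nc3ccccc23)cc1OCCN`, is not yet measured. It differs from compound 1 in one place: one nitrogen atom in place of a group of 7 heavy atoms (5 carbon, 1 nitrogen, 1 selenium; no ring), on a saturated chain carbon, two bonds along the chain from an oxygen on an aromatic ring. The selenium-bearing chain, present in every measured compound, is therefore gone, and only a short amino-terminated chain remains.

Among the measured compounds shown here, since no measured pair isolates this change, the expectation rests on compound 1 already being the weakest at 3550 nM and on every stronger compound keeping selenium. A loss of potency beyond the scatter is expected, in this assay by about a 3.4-fold higher number from compound 1 to compound 4 (0.53 log units; beyond the scatter). Compound 4 is estimated to give 12000 nM, within 2500 nM to 60000 nM.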

Compound 4, half-maximal inhibitory concentration: 682 nM
For compound 4 the middle estimate is 18-fold (1.25 log units) above the measured one, and the stated range ends above it.
By their numbers in this assay, from the lowest: compound 3; then compound 2; then compound 4; then compound 1.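

Compound 4 holds no selenium, yet in this assay the change from the selenium-bearing group to amino is a gain in potency (a 5.2-fold lower number from compound 1 to compound 4 (0.72 log units; beyond the scatter)). Every earlier compound carried selenium, so none could show that, at this place on the chain, removing it need not cost activity; the finding covers this one pair and says nothing about selenium elsewhere on the shared core. No measured evidence bears on what lies behind this step.

The change removes the selenium and shortens the chain in a single move, so the two cannot be told apart here. A longer chain ending in amino, or a hydroxyl or dimethylamino group on the same short chain, would help show whether the chain length or the end group matters.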